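The source may hold more compounds than are shown below. What is called first, only, known or untested is meant among the compounds shown, and "the series" means these compounds.

Compound 1 `CS(=O)(=O)Nc1ccc(CNC(=O)c2ccc(C3(C(F)(F)F)CC3)cc2)c(Cl)c1` gives 540 nM in an assay on HeLa cells for agonist activity at Bile acid receptor (Homo sapiens), read by a luciferase reporter, with a stated time of 24 h; a higher number here means that more compound is needed for the effect, a lower number that less compound is needed.
Compound 2 `CS(=O)(=O)Nc1ccc(CNC(=O)c2ccc(N3CCCCC3)cc2)c(Cl)c1` gives 410 nM in this assay.

Among the measured compounds shown here, compound 2 stands at the smaller of the two numbers, but the only step measured so far is a 1.3-fold lower number from compound 1 to compound 2 (0.12 log units; within the scatter), so the two compounds are not separated. Compound 3 `CS(=O)(=O)Nc1ccc(CNC(=O)c2ccc(OC(F)(F)F)cc2)c(Cl)c1` differs from compound 2 in that (trifluoromethoxy in place of piperidin-1-yl on an aromatic carbon). For the measured compounds named here, the one measured step that bears on a change at this position is a 1.3-fold lower number from compound 1 to compound 2 (0.12 log units; within the scatter), a change of the same kind that left the number where it was. For compound 3 no step beyond the scatter is therefore expected in this assay: a 1.5-fold higher number from compound 2 to compound 3 (0.17 log units; within the scatter). Compound 3 is estimated at 600 nM, in the range 250 nM to 1500 nM.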

Compound 3, half-maximal effective concentration: 1090 nM
Estimate against measurement, compound 3: 1.8-fold (0.26 log units) below; low and high end bracket the measured number.
By their numbers in this assay, from the lowest: compounds 2 and 1 (each within the scatter of the next); then compound 3.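

In this assay this position, on an aromatic carbon para to a large group, now proves sensitive to the group it carries, with a 2.7-fold higher number from compound 2 to compound 3 (0.42 log units; beyond the scatter) and a 2.0-fold higher number from compound 1 to compound 3 (0.31 log units; beyond the scatter) as modest steps in the same direction. Piperidin-1-yl and 1-(trifluoromethyl)cyclopropyl remain within the scatter of each other, so trifluoromethoxy is the first group in the series to separate from the others. No measurement shown gives a reason for this separation.

Open, as far as these compounds go, is whether a morpholin-4-yl ring, a carboxylic acid or a longer alkyl chain at this position would follow compound 3 or stay with compound 2.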